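An Aryl Group in Place of Propyl: Compound 4

A few compounds are considered here, and "the series" means these few. Any claim that something is new, unique, unknown or untested is made for them only; others in the source may bear on it.

Measured in an in vitro functional assay on cells for agonist activity at Bombesin receptor subtype-3 (Homo sapiens), read by luminescence and calcium flux; on this read-out lower numbers stand for an effect already at smaller amounts and higher numbers for an effect only at larger amounts of compound:
Compound 1, `CCCCc1cnc(CCc2ccc(-c3ccccc3C(=O)O)cc2)[nH]1`: 2710 nM
Compound 2, `N#Cc1cccc(Cc2cnc(CCc3ccc(-c4ccccc4C(=O)O)cc3)[nH]2)c1`: 812 nM
Compound 3, `CCCCc1cnc(/C=C/c2ccc(-c3ccccc3C(=O)O)cc2)[nH]1`: 4380 nM

Compound 1 stands second highest of the three numbers in this assay; compound 3 sits close to it within the scatter, while compound 2 gives the lowest number. Compound 4, `Cc1ccccc1Cc1cnc(CCc2ccc(-c3ccccc3C(=O)O)cc2)[nH]1`, differs from compound 1 by 2-methylphenyl in place of propyl on a saturated chain carbon bound to an aromatic carbon. Within the data shown here, the one measured step that bears on this change is a 3.3-fold lower number from compound 1 to compound 2 (0.52 log units; beyond the scatter), in which an aromatic ring likewise replaced propyl at the same place. Compound 4 is therefore expected to show a modest step downward in this assay as well, a 2.3-fold lower number from compound 1 to compound 4 (0.35 log units; beyond the scatter), though 2-methylphenyl is not 3-cyanophenyl and the size is uncertain. The estimate for compound 4 is 1200 nM, with a range from 400 nM to 3500 nM.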

Compound 4, half-maximal effective concentration: 127 nM
Compound 4: middle estimate off by 9.4-fold (0.98 log units), on the high side; measured number below the stated range.
By their numbers in this assay, from the lowest: compound 4; then compound 2; then compounds 1 and 3 (each within the scatter of the next).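

The aromatic replacement at this position can go much further than compound 2 showed: 2-methylphenyl in place of propyl gives a 21-fold lower number from compound 1 to compound 4 (1.33 log units; beyond the scatter) and, in place of 3-cyanophenyl, gives a 6.4-fold lower number from compound 2 to compound 4 (0.81 log units; beyond the scatter). The size of the gain therefore depends on which aromatic group enters, not just on an aromatic ring being present. Nothing available here explains the difference between these two aromatic groups.

On these data alone, it remains open whether plain phenyl, or a chlorine or methoxy group in place of the methyl, would keep this gain. As far as these compounds go, it also remains open whether 2-methylphenyl would give a similar step on the core of compound 3.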